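Clearance notes on the shared core: compound 2 to compound 3

A few compounds are considered here, and "the series" means these few. Any claim that something is new, unique, unknown or untested is made for them only; others in the source may bear on it.

Two members of the series have been run in an ADME assay on cells (Hepatocyte, Rattus norvegicus) for metabolic stability, read by LC-MS, using NADPH, with a stated time of 45 min, tested at 3 uM (a lower number here means slower removal, a higher number faster removal of the compound), so far. Compound 1 `Cc1c(-c2cncc(-c3ccc(OC(F)(F)F)cc3)c2)[nH]c2ccccc2c1=O` gives 1.8 uL/min in this assay. Compound 2 `COc1ccc2c(=O)c(C)c(-c3cncc(-c4ccc(Cl)c(Cl)c4)c3)[nH]c2c1` gives 4.9 uL/min in this assay, the higher of the two numbers; the gap from compound 1 to compound 2 lies beyond the usual scatter, so compound 2 is removed faster than compound 1 by this measure.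

Compound 3 `Cc1c(-c2cncc(-c3ccc(Cl)c(Cl)c3)c2)[nH]c2ccccc2c1=O` has not yet been run. It differs from compound 2 in one place: hydrogen in place of methoxy on an aromatic carbon. Among the compounds with values here, no measured pair in the set shows this exact change, so the size of the step is open. A step of modest size downward is expected from compound 2 to compound 3 in this assay, a 1.6-fold lower number from compound 2 to compound 3 (0.21 log units; within the scatter), with the possibility that it stays within the scatter; this expectation rests on compound 1, which also carries hydrogen at that position and gives 1.8 uL/min. Compound 3 is thus estimated at 3 uL/min in this assay, with a range from 1.5 uL/min to 6 uL/min.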

Compound 3, intrinsic clearance in a liver preparation (reported as CLH), per the amount of preparation that the assay uses: 9.9 uL/min
For compound 3 the middle estimate is 3.3-fold (0.52 log units) below the measured one; the whole stated range lies below it.
By their numbers in this assay, from the lowest: compound 1; then compound 2; then compound 3.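

In this assay, within the data shown here, this is the first pair that isolates this position on the shared core: hydrogen in place of methoxy gives a 2.0-fold higher number from compound 2 to compound 3 (0.31 log units; beyond the scatter). Of these two compounds, the one carrying methoxy, compound 2, is therefore removed more slowly, and the size of the step lies beyond the usual scatter, though it rests on this single pair. Nothing measured here accounts for the step.

Going by these compounds, whether the same change gives a step of similar direction and size with the trifluoromethoxy-substituted ring of compound 1 remains open. Also open, on these data alone, is how this assay would read with a hydroxyl group, an amine or a longer alkoxy chain such as ethoxy at this position.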